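The source may report more compounds than this note shows. Statements on the series, on what has been measured and on what is new or still open speak of the compounds shown alone.

Within the data shown here, in an assay on HEK293 cells for displacement of a labelled ligand from transient receptor potential cation channel subfamily V member 1 (Homo sapiens) (a higher number here means a weaker inhibitor, a lower number a stronger inhibitor), compound 2 `Cc1cccc(N2CCC(C(=O)Nc3ccc4c(c3)NC(=O)CO4)CC2)c1C` gives 28 nM, the lowest of the two numbers measured so far. Compound 1 `CC(C)c1ccccc1N1CCC(C(=O)Nc2ccc3c(c2)NC(=O)CO3)CC1` gives 78 nM. Among the measured compounds shown here, the only measured step is a 2.8-fold lower number from compound 1 to compound 2 (0.44 log units; beyond the scatter). Compound 3 `Cc1c(Cl)cccc1N1CCC(C(=O)Nc2ccc3c(c2)NC(=O)CO3)CC1` differs from compound 2 by chloro in place of methyl on an aromatic carbon. That single measured step concerns a different change, so nothing measured bears directly on exchanging methyl for chloro. For compound 3 the expectation is therefore no step beyond the scatter, a 1.1-fold higher number from compound 2 to compound 3 (0.03 log units; within the scatter). Compound 3 is estimated at 30 nM, with a range from 12 nM to 80 nM.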

Compound 3, inhibition constant: 100 nM
Compound 3: the middle estimate sits 3.3-fold (0.52 log units) below what was measured; the measured number lies above the stated range.
By their numbers in this assay, from the lowest: compound 2; then compounds 1 and 3 (each within the scatter of the next).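

In this assay, methyl and chloro are not interchangeable at this position on the aromatic ring: the exchange gives a 3.6-fold higher number from compound 2 to compound 3 (0.55 log units; beyond the scatter). The advantage of the 2,3-dimethylphenyl group is lost with 3-chloro-2-methylphenyl, which gives a 1.3-fold higher number from compound 1 to compound 3 (0.11 log units; within the scatter). Nothing measured here explains this difference. The compounds shown leave open how other groups at this position would read, such as methoxy, an amine or a nitrile. They also leave open whether chloro would give the same step without the ortho methyl group.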